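Cyclic ether in place of the open ethoxy chain

The compounds below may be only part of what the source reports. "The series", "measured", "known", "first", "only" and "open" are said of these compounds alone.

Measured so far in an assay on cells with melanin-concentrating hormone receptor 1 (Homo sapiens) as the target, read by radioligand binding; on this read-out higher numbers stand for weaker inhibition and lower numbers for stronger inhibition:
- compound 1, `Nc1ccc2cccc(OCCC3CCCCC3)c2n1`: compound 1 gives 808 nM
- compound 2, `CCOCC(C)Oc1cccc2ccc(N)nc12`: compound 2 gives 1070 nM
- compound 3, `CCOCCOc1cccc2ccc(N)nc12`: compound 3 gives > 2000 nM

The value for compound 3 is a limit of this assay, not a number; compound 3 sits at the limit of > 2000 nM in this assay, at which 1 of the 3 values shown sits. Compound 3 therefore stands at the weak end of the three, with compound 1 and compound 2 giving numbers.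

Compound 4, `Nc1ccc2cccc(OCC3CCOC3)c2n1`, is still to be measured. Its difference from compound 3 is oxolan-3-yl in place of ethoxymethyl on a saturated chain carbon bound to an oxygen on an aromatic ring.

Among the measured compounds shown here, two measured steps bear on this change. The step of an at least 2.4-fold higher number from compound 1 to compound 3 (0.39 log units; beyond the scatter) shows that the open ethoxy chain stands weaker than a cyclohexyl on that chain carbon. The step of an at least 1.8-fold higher number from compound 2 to compound 3 (0.27 log units; that floor lies within the scatter) shows that a methyl on the chain carbon bound to the aryl oxygen also reads as a lower number, though that floor lies within the scatter. Both point the same way: closing or building up the chain lowers the number. For compound 4 the oxolan-3-yl is expected to give a step of an at least 2.0-fold lower number from compound 3 to compound 4 (0.30 log units; that floor lies within the scatter), back into the region of compound 1 and compound 2. The estimate for compound 4 in this assay is 1000 nM, with a range from 350 nM to 2800 nM.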

Compound 4, half-maximal inhibitory concentration: 115 nM
Compound 4: the middle estimate sits 8.7-fold (0.94 log units) above what was measured; the measured number lies below the stated range.
By their numbers in this assay, from the lowest: compound 4; then compounds 1 and 2 (each within the scatter of the next). At a limit, above all of these: compound 3.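

In this assay, closing the open chain into the ring gives an at least 17-fold lower number from compound 3 to compound 4 (1.24 log units; beyond the scatter), although the group that leaves and the group that enters both carry 1 hydrogen-bond acceptor and no net charge, so at this place the ether oxygen alone does not set the reading. The value of compound 3 is a limit of the assay and not a number, so that step is a floor: the limit of > 2000 nM in this assay, at which 1 of the 4 values shown sits. The branched open chain of compound 2 separates the ring from mere bulk, since a 9.3-fold lower number from compound 2 to compound 4 (0.97 log units; beyond the scatter) arises between two groups of equal heavy-atom count on the oxygen on the aromatic ring, one with a ring and one without, so among these compounds the ring goes with the lower number and the group size does not.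

Going by these compounds, whether the ring oxygen of the oxolan-3-yl contributes at all stays open, and a cyclopentyl on the same chain carbon would test this directly. Equally open, on these data alone, are how a six-membered oxan-4-yl or a ring amine such as pyrrolidin-3-yl would read here, and whether the ring tolerates a shorter or longer link to the oxygen on the aromatic ring.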